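The source may report more compounds than this note shows. Statements on the series, on what has been measured and on what is new or still open speak of the compounds shown alone.

Of the compounds shown here, two sharing one core have been measured so far in an ADME assay on cells (Hepatocyte, Homo sapiens) for metabolic stability; a higher number here means faster removal of the compound, a lower number slower removal. Among the measured compounds shown here, compound 1 `COCc1cc(-c2cnn(C)c2-c2sc3ccccc3c2C#N)cc2c(CN)n[nH]c(=O)c12` gives 66 mL/min/kg and compound 2 `Cn1ncc(-c2cc(Cl)c3c(=O)[nH]nc(CN)c3c2)c1-c1sc2ccccc2c1C#N` gives 71 mL/min/kg, so compound 2 stands level with its only neighbour within the scatter. The next compound, compound 3 `Cn1ncc(-c2cc(C(F)F)c3c(=O)[nH]nc(CN)c3c2)c1-c1sc2ccccc2c1C#N`, differs from compound 2 in a single group: difluoromethyl in place of chloro on an aromatic carbon. For the measured compounds named here, one measured step bears on this same carbon, a 1.1-fold higher number from compound 1 to compound 2 (0.03 log units; within the scatter), where chloro replaced methoxymethyl, and it lies within the scatter. Going by the values given here, that is only one step, and difluoromethyl has not yet been measured at this carbon, so the evidence is thin. Even so, no clear move in either direction is expected in this assay. The expected size of the change is a 1.0-fold lower number from compound 2 to compound 3 (0.02 log units; within the scatter), which would stay within the scatter. The estimated value for compound 3 is 68 mL/min/kg, with an expected range of 40 mL/min/kg to 105 mL/min/kg.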

Compound 3, clearance: 44 mL/min/kg
Compound 3: middle estimate off by 1.5-fold (0.19 log units), on the high side; low and high end bracket the measured number.
By their numbers in this assay, from the lowest: compounds 3, 1 and 2 (each within the scatter of the next).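

On this aromatic carbon, difluoromethyl in place of chloro gives a 1.6-fold lower number from compound 2 to compound 3 (0.21 log units; within the scatter) in this assay and difluoromethyl in place of methoxymethyl gives a 1.5-fold lower number from compound 1 to compound 3 (0.18 log units; within the scatter) on the same scale. Three different groups have now been seen at this one carbon, and all three compounds lie within the usual scatter of one another, so none of these swaps shows a clear effect on clearance in this set. No measurement is available here that could explain the values of these compounds.

As far as these compounds go, whether this carbon tolerates quite different groups just as evenly, such as an amine, a carboxylic acid or a longer chain, remains open. From the compounds shown here alone, all three compounds also share the rest of their structure, so what changes at other places would do to clearance is unknown.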